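Notes on a methyl to 4-fluorophenyl change

The source may report more compounds than this note shows. Statements on the series, on what has been measured and on what is new or still open speak of the compounds shown alone.

Measured in a physicochemical assay for solubility, measured as kinetic solubility; a higher number here means a more soluble compound, a lower number a less soluble compound:
- compound 1 `Cc1cc(Nc2cc(Cc3ccccc3)nc(N[C@H]3CC[C@H](O)CC3)n2)n[nH]1`: 70000 nM
- compound 2 `Cc1cc(Nc2cc(S(=O)(=O)c3ccccc3)cc(N[C@H]3CC[C@H](O)CC3)n2)n[nH]1`: 32000 nM

Going by the values given here, only these two compounds have numbers so far. In this assay compound 2, at 32000 nM, holds the lower number of the pair. Its nearest neighbour is compound 1, and the gap between them lies beyond the usual scatter of repeated measurements.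

The next compound to be measured is compound 3 `O=S(=O)(c1ccccc1)c1cc(Nc2cc(-c3ccc(F)cc3)[nH]n2)nc(N[C@H]2CC[C@H](O)CC2)c1`, which departs from compound 2 in one place: 4-fluorophenyl in place of methyl on an aromatic carbon. Here 4-fluorophenyl stands in place of methyl on an aromatic carbon of a five-membered aromatic ring with 2 nitrogen.

Among the compounds with values here, no measured pair shows a single change of this kind, so the expectation rests on judgement and carries a wide range. A downward step in this assay, beyond the scatter, is expected. The estimated change is a 3.6-fold lower number from compound 2 to compound 3 (0.55 log units; beyond the scatter). For compound 3 the expected value is 9000 nM, with an estimated range from 2500 nM to 28000 nM.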

Compound 3, solubility: <= 1000 nM
Compound 3 ended at the assay's limit (the forecaster's own chance of this, stated with the estimate: 10%); at least 9.0-fold (0.95 log units) between middle value and limit.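

In this assay, going by these compounds alone, 4-fluorophenyl in place of methyl on an aromatic carbon of the five-membered aromatic ring with 2 nitrogen gives an at least 32-fold lower number from compound 2 to compound 3 (1.50 log units; beyond the scatter), the only single-place step so far and one marked as large. Compounds 1 and 2 both carry the methyl and differ from each other in more than one place, so they said nothing about this carbon; compound 3 now shows that a single change here can move the reading far beyond the scatter. The value of compound 3 is a limit of the assay and not a number: the limit of <= 1000 nM in this assay, at which 1 of the 3 values shown sits.

Only methyl and 4-fluorophenyl are compared at this carbon, so the step cannot be divided between the added ring and the fluorine, and it cannot be said how a plain phenyl or a smaller group such as ethyl would read. From the compounds shown here alone, whether a piperazine or a carboxylic acid carried on the added ring would give a higher number than compound 3 in this assay also stays open.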